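A few compounds are considered here, and "the series" means these few. Any claim that something is new, unique, unknown or untested is made for them only; others in the source may bear on it.

Measured so far:
compound 1, `CCCCOc1nc(N)c2[nH]c(=O)n(Cc3ccccc3)c2n1`, 0.001 uM
compound 2, `NNc1nc2c(N)ncnc2n1Cc1ccccc1`, > 10 uM
compound 3, `CCCCNc1nc(N)c2nc(O)n(Cc3ccccc3)c2n1`, 1 uM

In a functional assay (spleen, spleen) for activation, with Mus musculus as the target (on this read-out higher numbers stand for an effect only at larger amounts of compound and lower numbers for an effect already at smaller amounts), compound 1 gives 0.001 uM, and compound 3 gives 1 uM. For compound 2 the figure > 10 uM is a limit of this assay and not a number. Compound 2 thus stands at the limit of > 10 uM in this assay, at which 1 of the 3 values shown sits, so there is no value of its own to step from. Compound 4, `Cc1nc2c(N)ncnc2n1Cc1ccccc1`, is not yet measured in this assay. It differs from compound 2 by methyl in place of aminoamino on an aromatic carbon. For the measured compounds named here, no step between measured compounds is known, so the size of going from the aminoamino group to the methyl has no precedent in this set. The expectation is that compound 4 stays weak, with an estimate of 10 uM, between 2 uM and 30 uM, and an expected step of a number no higher from compound 2 to compound 4 (the limit leaves the size open) that may again end at a limit.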

Compound 4, minimum effective concentration: > 10 uM
Compound 4: no number, only a limit; the forecaster's own chance of this, stated with the estimate: 60%; the middle value sits exactly at the limit.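

In this assay compound 2 and compound 4 both stand at a limit and not a number, so no step between them can be read: the limit of > 10 uM in this assay, at which 2 of the 4 values shown sit.

From the compounds shown here alone, how far methyl and aminoamino on this aromatic carbon differ remains open.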